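Trichlorophenyl variant in a series sitting at the limit

A few compounds are considered here, and "the series" means these few. Any claim that something is new, unique, unknown or untested is made for them only; others in the source may bear on it.

Compound 3 `Cc1ccc(-n2nncc2CN2C(=O)C3(C(C#N)=C(N)Oc4c(N)cc5nc6ccccc6nc5c43)c3ccccc32)cc1Cl` belongs to a small set of three close relatives tested in a functional assay on HCT-116 cells (Homo sapiens) for antiproliferative activity, read by MTT assay, with a stated time of 48 h; a lower number here means a stronger inhibitor, a higher number a weaker inhibitor. In this assay compound 3 gives > 50000 nM, which is a limit of the assay rather than a number. Its two companions stand the same way. Compound 1 `Cc1ccccc1-n1nncc1CN1C(=O)C2(C(C#N)=C(N)Oc3c(N)cc4nc5ccccc5nc4c32)c2ccccc21` gives > 50000 nM, a limit. Compound 2 `N#CC1=C(N)Oc2c(N)cc3nc4ccccc4nc3c2C12C(=O)N(Cc1cnnn1-c1ccccc1Cl)c1ccccc12` gives > 50000 nM, also a limit. Because (the limit of > 50000 nM in this assay, at which 3 of the 3 values shown sit), the steps a step that the two limits leave unreadable from compound 1 to compound 2, a step that the two limits leave unreadable from compound 1 to compound 3 and a step that the two limits leave unreadable from compound 2 to compound 3 cannot be read in size or direction. Compound 4 `N#CC1=C(N)Oc2c(N)cc3nc4ccccc4nc3c2C12C(=O)N(Cc1cnnn1-c1c(Cl)cc(Cl)cc1Cl)c1ccccc12` differs from compound 3 by 2,4,6-trichlorophenyl in place of 3-chloro-4-methylphenyl on an aromatic nitrogen. Each measured step likewise swaps the group on the aromatic nitrogen, and none of them produced a readable number; what they show is that three such swaps left the potency at the limit, so they give no direction for this one. Compound 4 is therefore expected to remain at or near that limit, the step that the limit leaves unreadable from compound 3 to compound 4 being expected to stay small. The estimate for compound 4 in this assay is 80000 nM, between 20000 nM and 300000 nM.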

Compound 4, half-maximal inhibitory concentration: 12100 nM
For compound 4 the middle estimate is 6.6-fold (0.82 log units) above the measured one; measured number below the stated range.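

In this assay, the group on the aromatic nitrogen now proves able to change the result: 2,4,6-trichlorophenyl gives an at least 4.1-fold lower number from compound 3 to compound 4 (0.61 log units; beyond the scatter), and the same group gives an at least 4.1-fold lower number from compound 2 to compound 4 (0.61 log units; beyond the scatter) and an at least 4.1-fold lower number from compound 1 to compound 4 (0.61 log units; beyond the scatter). Among the compounds shown here, the steps among compounds 1, 2 and 3 cannot be read, so compound 4 provides the first readable evidence that this position affects the read-out. All three new steps remain bounds rather than full sizes because each starts from a compound at a limit: the limit of > 50000 nM in this assay, at which 3 of the 4 values shown sit.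

The compounds shown leave open whether the gain depends on the number of chlorine atoms or on where they sit, and a dichlorophenyl group would help to separate the two. They also leave open how a phenyl ring carrying an amine or a carboxylic acid would behave at this position.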